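Removing the Chloro Group from Compound 1

The source may hold more compounds than are shown below. What is called first, only, known or untested is meant among the compounds shown, and "the series" means these compounds.

Compound 1 `Cc1nnc(SCc2coc3ccc(Cl)cc3c2=O)o1` was tested in a functional assay on SW480 cells (Homo sapiens) for cytotoxicity, read by MTT assay, with a stated time of 72 h (a lower number here means a stronger inhibitor, a higher number a weaker inhibitor), where compound 1 gives 3500 nM. Compound 2 `Cc1nnc(SCc2coc3ccc(Cl)cc3c2=O)s1` gives 3200 nM in this assay, and the step of a 1.1-fold lower number from compound 1 to compound 2 (0.04 log units; within the scatter) shows that swapping the ring on sulfur makes no difference beyond the scatter. Compound 3 `Cc1cc(C)nc(SCc2cc(=O)c3ccccc3o2)n1` reached only the limit > 25000 nM in this assay, which is not a number but the edge of what was measured. Among the numbers shown, compound 1 has the highest of the two, with compound 2 as its nearest neighbour at a gap within the scatter.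

Compound 4 `Cc1nnc(SCc2coc3ccccc3c2=O)o1` differs from compound 1 by hydrogen in place of chloro on an aromatic carbon. Going by the values given here, no measured step isolates this change: the only step in hand, a 1.1-fold lower number from compound 1 to compound 2 (0.04 log units; within the scatter), concerns the ring on sulfur, not the chloro group. Compound 3 also lacks a chloro group, but it differs from compound 1 in several other places as well, so its limit cannot be read as the effect of the chloro group alone.

With no direct guide, compound 4 is estimated at 6000 nM in this assay, with a range from 2500 nM to 16000 nM. The expected step of a 1.7-fold higher number from compound 1 to compound 4 (0.23 log units; within the scatter) is a modest weakening and remains an estimate.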

Compound 4, half-maximal inhibitory concentration: 790 nM
For compound 4 the middle estimate is 7.6-fold (0.88 log units) above the measured one, outside the stated range (below it).
By their numbers in this assay, from the lowest: compound 4; then compounds 2 and 1 (each within the scatter of the next). At a limit, above all of these: compound 3.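

In this assay, replacing the chloro group with hydrogen gives a 4.4-fold lower number from compound 1 to compound 4 (0.65 log units; beyond the scatter), so what sits on this aromatic carbon matters to the read-out, and the chloro group is not needed for compound 4 to act on these cells. The earlier step, a 1.1-fold lower number from compound 1 to compound 2 (0.04 log units; within the scatter), changed the ring on sulfur and stayed within the scatter, so this is the first single change shown that moves the number beyond the scatter, and here removing an atom gives the stronger inhibitor. Nothing measured here bears on what lies behind this gain.

Going by these compounds, only chloro and hydrogen can be compared on this carbon, so it remains open whether a fluoro group, a methoxy group or an amine in the same place would give a number nearer to that of compound 1 or to that of compound 4. On these data alone, it also remains open whether the same exchange of chloro for hydrogen would pay off to a similar extent with the 5-methyl-1,3,4-thiadiazol-2-yl ring of compound 2 on the sulfur.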